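Working notes: methyl for chloro on the aryl carbonyl

The compounds below may be only part of what the source reports. "The series", "measured", "known", "first", "only" and "open" are said of these compounds alone.

Compound 1 `COc1ccc(C(=O)c2cc(C)ccc2OCC(=O)NNC(=O)c2cc3ccccc3oc2=O)cc1` gives 42000 nM in a functional assay on DLA cells (Mus musculus) for cytotoxicity, read by MTT assay, with a stated time of 48 h; a higher number here means a weaker inhibitor, a lower number a stronger inhibitor.
Compound 2 `Cc1ccc(OCC(=O)NNC(=O)c2cc3ccccc3oc2=O)c(C(=O)c2cccc(Cl)c2)c1` gives 65500 nM in this assay.
Compound 3 `Cc1ccc(OCC(=O)NNC(=O)c2cc3ccccc3oc2=O)c(C(=O)c2ccc(Cl)cc2)c1` gives 59100 nM in this assay.

Compound 3 stands second highest of the three numbers; its nearest neighbour is compound 2, with a step of a 1.1-fold lower number from compound 2 to compound 3 (0.04 log units; within the scatter), and the furthest is compound 1, with a step of a 1.4-fold higher number from compound 1 to compound 3 (0.15 log units; within the scatter). Compound 4 `Cc1ccc(C(=O)c2cc(C)ccc2OCC(=O)NNC(=O)c2cc3ccccc3oc2=O)cc1` differs from compound 3 by methyl in place of chloro on an aromatic carbon. Every change so far on this carbonyl-linked ring has stayed within the scatter, including a 1.6-fold higher number from compound 1 to compound 2 (0.19 log units; within the scatter). No step beyond the scatter is therefore expected for compound 4 in this assay, and the change is estimated at a 1.1-fold lower number from compound 3 to compound 4 (0.03 log units; within the scatter). Compound 4 is estimated at 55000 nM, with a range from 25000 nM to 120000 nM.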

Compound 4, half-maximal inhibitory concentration: 84600 nM
Compound 4: middle estimate off by 1.5-fold (0.19 log units), on the low side, within the range that was stated.
By their numbers in this assay, from the lowest: compounds 1, 3, 2 and 4 (each within the scatter of the next).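

In this assay, chloro to methyl on the aromatic carbon para to a large group stays within the scatter (a 1.4-fold higher number from compound 3 to compound 4 (0.16 log units; within the scatter)), so this position tolerates a swap between these two single-atom groups without a readable change. The other two steps to compound 4 are also within the scatter (a 1.3-fold higher number from compound 2 to compound 4 (0.11 log units; within the scatter); a 2.0-fold higher number from compound 1 to compound 4 (0.30 log units; within the scatter)), so methoxy, chloro and methyl cannot be told apart here. No measurement on hand bears on these steps.

From the compounds shown here alone, whether an amine or a carboxylic acid on this ring would give a step beyond the scatter remains open. So does any effect of changes elsewhere on the shared core.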